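The compounds below may be only part of what the source reports. "The series", "measured", "known", "first", "only" and "open" are said of these compounds alone.

Measured so far:
compound 1 `Clc1ccc2c(NCCN3CCCCCC3)ccnc2c1`: 13200 nM
compound 2 `CN1CCN(CC(=O)N2CCN(c3ccnc4cc(Cl)ccc34)CC2)CC1`: 79800 nM

In a toxicity assay (L6 cells) for inhibition, with Rattus norvegicus as the target, read by resazurin assay, with a stated time of 70 h (a lower number here means a stronger inhibitor, a higher number a weaker inhibitor), compound 1 has the lower of the two numbers, and the gap up to compound 2 lies beyond the usual scatter. Not yet measured is compound 3 `CCCN(CCC)CCNc1ccnc2cc(Cl)ccc12`. Its difference from compound 1 is dipropylamino in place of azepan-1-yl on a saturated chain carbon, two bonds along the chain from a nitrogen on an aromatic ring.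

For the measured compounds named here, no two measured compounds differ in one place only, so the data hold no direct precedent for this change. The entering and leaving groups match in everything counted except the ring, and no step beyond the scatter is expected in this assay, in either direction. The expectation therefore stays anchored on compound 1 at 13200 nM. The estimated step is a 1.1-fold higher number from compound 1 to compound 3 (0.06 log units; within the scatter). The expected value for compound 3 is 15000 nM, with an estimated range of 6000 nM to 38000 nM.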

Compound 3, half-maximal inhibitory concentration: 14900 nM
Compound 3: middle estimate off by 1.0-fold (0.00 log units), on the high side, and the stated range covers the measured number.
By their numbers in this assay, from the lowest: compounds 1 and 3 (each within the scatter of the next); then compound 2.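

In this assay, for the compounds shown here, dipropylamino in place of azepan-1-yl on a saturated chain carbon, two bonds along the chain from a nitrogen on an aromatic ring, gives a 1.1-fold higher number from compound 1 to compound 3 (0.05 log units; within the scatter) and so provides the first one-place comparison. For this pair, the ring in the terminal group is not required to keep the number within the scatter, with heavy atoms, hydrogen-bond counts and net charge the same on both sides. Nothing measured here bears on why the two groups read alike.

Open, as far as these compounds go, is whether a smaller terminal group such as diethylamino, or a piperidin-1-yl or morpholin-4-yl ring, at the same place would also stay within the scatter. Also open, from the compounds shown here alone, is how a longer chain between the two nitrogens would read in this assay.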